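A Methyl Step Carried Over to a Second Core

The source may report more compounds than this note shows. Statements on the series, on what has been measured and on what is new or still open speak of the compounds shown alone.

Compound 1 `CNCc1cc(-c2ccccc2)n(S(=O)(=O)c2ccc(C)cc2)c1` and compound 2 `CNCc1cc(-c2ccccc2)n(S(=O)(=O)c2ccccc2)c1` share one core and differ only by methyl in place of hydrogen on an aromatic carbon. In a physicochemical assay for lipophilicity, read by HPLC, at pH 7.4 (on this read-out lower numbers stand for lower lipophilicity and higher numbers for higher lipophilicity), compound 2 gives 1.44, and compound 1 gives 1.83; the step here is a number 0.39 log units higher from compound 2 to compound 1 (beyond the scatter). Compound 3 `CNCc1cc(-c2cccnc2F)n(S(=O)(=O)c2cccnc2)c1` is built on a second core; the difference between the two cores is not broken down here. In this assay compound 3 gives -0.85, the lowest of the three numbers, and its value lies well apart from those of compound 2 and compound 1. Compound 4 `CNCc1cn(S(=O)(=O)c2cccnc2)c(-c2cccnc2F)c1C` has not yet been measured; it differs from compound 3 by methyl in place of hydrogen on an aromatic carbon. This is the same kind of change as that from compound 2 to compound 1, though the place is not the same: there the methyl enters on a six-membered aromatic ring of carbon only, para to a large group, here on a five-membered aromatic ring with 1 nitrogen, next to the ring atom that bears a (methylamino)methyl group and next to the ring atom that bears a 2-fluoropyridin-3-yl group. For compound 4 the step is expected to be a number 0.40 log units higher from compound 3 to compound 4 (beyond the scatter), set beside the earlier measured step of a number 0.39 log units higher from compound 2 to compound 1 (beyond the scatter), since that is the only methyl step measured among these compounds. In this assay compound 4 is therefore expected to give -0.45, most likely between -0.9 and 0.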

Compound 4, distribution coefficient: -0.4
Compound 4: the middle estimate sits 0.05 log units below what was measured; the measured number falls inside the stated range.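

In this assay the methyl change on the core of compound 3 gives a number 0.45 log units higher from compound 3 to compound 4 (beyond the scatter), set beside a number 0.39 log units higher from compound 2 to compound 1 (beyond the scatter) on the other core: the two steps run the same way and both rank as modest, although the methyl enters at different places. Across these two pairs, then, the change carried from one core to the other with its direction and approximate size kept, and no compound shown goes against this. Two pairs do not establish a rule for the series, however; they cannot separate the effect of the core from that of the place, and no measurement shown explains the size of either step.

The compounds shown leave open whether ethyl or a longer chain, in the same place on the five-membered aromatic ring, would give a step of similar size. They also leave open whether methyl on the 2-fluoropyridin-3-yl group would move the number as these two steps did.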